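Trimming One Ring Substituent and Asking About Cell Tolerance

A few compounds are considered here, and "the series" means these few. Any claim that something is new, unique, unknown or untested is made for them only; others in the source may bear on it.

Of the compounds shown here, two have so far been tested in an ADME assay on HEL cells (Homo sapiens) for cytotoxicity; a higher number here means that more compound is tolerated, a lower number that less compound is tolerated. Compound 1 `C/C(=N\NC(=O)COc1cccc2ccccc12)c1ccc(C#N)cc1Br` gives 12.7 ug/mL, the higher of the two numbers. Compound 2 `O=C(COc1cccc2ccccc12)N/N=C/c1ccccc1O` gives 3.57 ug/mL in this assay, a lower figure, and the gap between the two lies beyond the usual scatter of repeated measurements. Compound 3 `C/C(=N\NC(=O)COc1cccc2ccccc12)c1ccc(Br)cc1` has not yet been measured. It differs from compound 1 in one place: 4-bromophenyl in place of 2-bromo-4-cyanophenyl on a carbon with a double bond to nitrogen. The shared core is untouched; only the aromatic group on the carbon with a double bond to nitrogen changes, and the cyano group is gone. For the measured compounds named here, no measured pair here shows a change of this kind, so there is no comparable step to lean on. With nothing pointing either way, the step from compound 1 to compound 3 is expected to be small, a 1.3-fold lower number from compound 1 to compound 3 (0.10 log units; within the scatter), and not clearly beyond the scatter. Compound 3 is therefore estimated to give about 10 ug/mL in this assay, with a plausible range from 4 ug/mL to 25 ug/mL.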

Compound 3, half-maximal cytotoxic concentration: 15.3 ug/mL
Compound 3: the middle estimate sits 1.5-fold (0.18 log units) below what was measured; the range from low to high includes it.
By their numbers in this assay, from the lowest: compound 2; then compounds 1 and 3 (each within the scatter of the next).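

Replacing 2-bromo-4-cyanophenyl with 4-bromophenyl on a carbon with a double bond to nitrogen gives a 1.2-fold higher number from compound 1 to compound 3 (0.08 log units; within the scatter) in this assay, so the two compounds cannot be told apart in this read-out. For the compounds shown here, this is the first direct comparison of two compounds that differ in one place, and it shows that this aromatic group can lose its nitrile and carry its bromine as 4-bromophenyl with no change beyond the scatter. Nothing available here explains this result.

The single step alters the nitrile and the bromine together, so the compounds shown cannot separate what each one contributes. On these data alone, it also remains open whether an amine or a carboxylic acid on this aromatic ring would move the number beyond the scatter.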